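The source may hold more compounds than are shown below. What is called first, only, known or untested is meant among the compounds shown, and "the series" means these compounds.

Three compounds share one core and differ only in the group carried on a saturated chain carbon bound to an oxygen on an aromatic ring. Compound 1 `Cc1cc(C(=O)O)nn1Cc1cc(Br)ccc1OCc1ccccc1` carries a plain phenyl there, and in a functional assay on CHO-K1 cells for antagonist activity at prostaglandin E2 receptor EP1 subtype (Homo sapiens), read by FLIPR (a higher number here means a weaker inhibitor, a lower number a stronger inhibitor), compound 1 gives 15.1 nM. Compound 2 `Cc1cc(C(=O)O)nn1Cc1cc(Br)ccc1OCc1ccc(Cl)cc1Cl` carries a 2,4-dichlorophenyl, and in this assay compound 2 gives 0.49 nM, a move of a 31-fold lower number from compound 1 to compound 2 (1.49 log units; beyond the scatter). Compound 3 `Cc1cc(C(=O)O)nn1Cc1cc(Br)ccc1OCc1c(F)cccc1F` carries a 2,6-difluorophenyl, and in this assay compound 3 gives 105 nM, the highest number of the three, reached by a 7.0-fold higher number from compound 1 to compound 3 (0.84 log units; beyond the scatter) and by a 210-fold higher number from compound 2 to compound 3 (2.33 log units; beyond the scatter).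

Compound 4 `Cc1cc(C(=O)O)nn1Cc1cc(Br)ccc1OCc1cccc(Br)c1` is not yet measured. Its change from compound 3 is 3-bromophenyl in place of 2,6-difluorophenyl on a saturated chain carbon bound to an oxygen on an aromatic ring. Within the data shown here, two measured steps bear on this. The step of a 7.0-fold higher number from compound 1 to compound 3 (0.84 log units; beyond the scatter) shows that the two fluorines gave a weaker inhibitor than the plain phenyl, while a 31-fold lower number from compound 1 to compound 2 (1.49 log units; beyond the scatter) shows that two chlorines arranged differently gave a much stronger one. Replacing the difluoro pattern with a single bromine removes the arrangement that gave the weakest result, so a lower number is expected, probably nearer compound 1 than compound 2. Compound 4 is estimated at 8 nM, with a range from 2 nM to 40 nM. The expected step is a 13-fold lower number from compound 3 to compound 4 (1.12 log units; beyond the scatter).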

Compound 4, inhibition constant: 129 nM
Beside the measured number, compound 4's estimate is 16-fold (1.21 log units) below it; the whole stated range lies below it.
By their numbers in this assay, from the lowest: compound 2; then compound 1; then compounds 3 and 4 (each within the scatter of the next).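

Replacing the 2,6-difluorophenyl with the 3-bromophenyl gives a 1.2-fold higher number from compound 3 to compound 4 (0.09 log units; within the scatter), so this assay does not separate these two differently halogenated groups. Placing bromo in place of hydrogen on the plain phenyl gives an 8.5-fold higher number from compound 1 to compound 4 (0.93 log units; beyond the scatter), which shows that adding a halogen at this position does not by itself give a stronger inhibitor. The distance to the 2,4-dichlorophenyl is far larger, at a 260-fold higher number from compound 2 to compound 4 (2.42 log units; beyond the scatter), so among these four compounds the strong result belongs to that one group, while the 2,6-difluorophenyl and the 3-bromophenyl go against any rule that halogens in general help here.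

Nothing available explains these differences. The compounds shown leave open whether a 2-chlorophenyl or a 4-chlorophenyl alone would keep part of the strength of the 2,4-dichlorophenyl, or whether both chlorines are needed together.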